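Compound 1 to compound 3: methoxy added

This account rests on a few compounds, and the source may have more. Where it says the series, first, only, none or still open, it means among the compounds named here.

Among the compounds with values here, in a physicochemical assay, read by spectrophotometry, with a stated time of 6 min (a lower number here means a stronger inhibitor, a higher number a weaker inhibitor), two compounds have numbers so far. Compound 1 `O=C(CCc1nc2ccccc2c(=O)[nH]1)N/N=C/c1ccc(O)c(O)c1` gives 40000000 nM, the lower of the two, and compound 2 `O=C(CCc1nc2ccccc2c(=O)[nH]1)N/N=C/c1ccc([N+](=O)[O-])cc1` gives 220000000 nM. Within the data shown here, the one measured step, a 5.5-fold higher number from compound 1 to compound 2 (0.74 log units; beyond the scatter), is modest but beyond the scatter. It comes with 4-nitrophenyl in place of 3,4-dihydroxyphenyl.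

Compound 3 `COc1cc(/C=N/NC(=O)CCc2nc3ccccc3c(=O)[nH]2)cc(O)c1O` has not yet been measured. It differs from compound 1 by methoxy in place of hydrogen on an aromatic carbon, ortho to a hydroxy group, meta to a hydroxy group and meta to a large group. Among the measured compounds shown here, no measured step tests a methoxy, so the evidence is indirect. The scale comes from a 5.5-fold higher number from compound 1 to compound 2 (0.74 log units; beyond the scatter), a change that removes both hydroxy groups, whereas compound 3 keeps them. A smaller change is therefore expected here, with a slight rise in the number if any change appears. The expected step is a 1.3-fold higher number from compound 1 to compound 3 (0.10 log units; within the scatter), probably not beyond the scatter. For compound 3 the estimate is 50000000 nM, with an expected range of 20000000 nM to 130000000 nM.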

Compound 3, half-maximal inhibitory concentration: 40000000 nM
Estimate against measurement, compound 3: 1.3-fold (0.10 log units) above; the measured number falls inside the stated range.
By their numbers in this assay, from the lowest: compounds 1 and 3 (each within the scatter of the next); then compound 2.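

In this assay, within the data shown here, methoxy in place of hydrogen on an aromatic carbon, ortho to a hydroxy group, meta to a hydroxy group and meta to a large group, gives a first reading at this position (no change at the digits printed from compound 1 to compound 3 (within the scatter)). Adding this group to the ring of compound 1 therefore leaves the number in place while both hydroxy groups remain, so this aromatic carbon accepts methoxy in this assay. The larger earlier step (a 5.5-fold higher number from compound 1 to compound 2 (0.74 log units; beyond the scatter)) came from replacing the whole 3,4-dihydroxyphenyl with 4-nitrophenyl, and it says nothing about this carbon; no measurement at hand accounts for the unchanged number.

One methoxy at one position does not show how far this tolerance extends: ethoxy, an amine or a carboxylic acid on the same aromatic carbon could behave differently. The step from compound 1 to compound 2 also changes both hydroxy groups and adds a nitro group at once, so a phenyl carrying a single hydroxy group would be needed to separate those contributions.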